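The compounds below may be only part of what the source reports. "The series", "measured", "known", "first", "only" and "open" are said of these compounds alone.

Compound 1 `O=C1N=C(N2CCC[C@H]2C(=O)Nc2ccc3ncnc(Nc4cccc(Cl)c4)c3c2)S/C1=C/c1cccc(Cl)c1` carries a 3-chlorophenyl on a double-bonded chain carbon bound to a double-bonded ring carbon. In a functional assay on A549 cells (Homo sapiens) for antiproliferative activity, read by MTT assay (a lower number here means a stronger inhibitor, a higher number a weaker inhibitor), compound 1 gives only a limit, > 50000 nM, and no number. Two companions on the same core are known. Compound 2 `Cc1cccc(/C=C2/SC(N3CCC[C@H]3C(=O)Nc3ccc4ncnc(Nc5cccc(Cl)c5)c4c3)=NC2=O)n1` gives 8500 nM in this assay. Compound 3 `O=C1N=C(N2CCC[C@H]2C(=O)Nc2ccc3ncnc(Nc4cccc(Cl)c4)c3c2)S/C1=C/c1ccccc1Br` likewise reaches only a limit in this assay, > 50000 nM. Compound 1 therefore stands at the weak end of what is shown, a position it shares with compound 3 (the limit of > 50000 nM in this assay, at which 2 of the 3 values shown sit).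

For the measured compounds named here, compound 4 `O=C1N=C(N2CCC[C@H]2C(=O)Nc2ccc3ncnc(Nc4cccc(Cl)c4)c3c2)S/C1=C/c1ccccc1F` is the next member. 2-fluorophenyl in place of 3-chlorophenyl on a double-bonded chain carbon bound to a double-bonded ring carbon Of the measured steps, the one from compound 1 to compound 3 swaps the same group for another halogen-bearing phenyl and a step that the two limits leave unreadable from compound 1 to compound 3, whereas an at least 5.8-fold lower number from compound 1 to compound 2 (0.76 log units; beyond the scatter), so only the pyridyl brought the number down from the limit. A halogen shifted on a phenyl ring left compound 3 at the limit, and the fluorine of compound 4 is a move of the same kind. Compound 4 is thus expected to remain near the limit, with the step of a number no higher from compound 1 to compound 4 (the limit leaves the size open) unlikely to be readable. The estimate for compound 4 in this assay is 50000 nM, between 15000 nM and 200000 nM.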

Compound 4, half-maximal inhibitory concentration: 34500 nM
Compound 4: the middle estimate sits 1.4-fold (0.16 log units) above what was measured; measured number inside the range.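

In this assay, compound 4 is the only halogen-bearing phenyl member shown that gives a measured number and not a limit, so this place on a double-bonded chain carbon bound to a double-bonded ring carbon can yield a reading without a pyridyl group. That reading does not establish a real gain over the other halogen-bearing phenyl compounds: the data give an at least 1.4-fold lower number from compound 1 to compound 4 (0.16 log units; that floor lies within the scatter) and an at least 1.4-fold lower number from compound 3 to compound 4 (0.16 log units; that floor lies within the scatter), and each is a floor and not a size. The comparison with the pyridyl member is firmer, with a 4.1-fold higher number from compound 2 to compound 4 (0.61 log units; beyond the scatter), so the 6-methylpyridin-2-yl of compound 2 keeps a modest lead over the 2-fluorophenyl of compound 4.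

Compounds 1 and 3 each remain at a limit, which leaves their true distance from compound 4 unknown: the limit of > 50000 nM in this assay, at which 2 of the 4 values shown sit. With 3-chlorophenyl and 2-bromophenyl as the nearest comparisons, the compounds shown cannot separate the identity of the halogen from its place on the ring, and they leave open how 3-fluorophenyl, 2-chlorophenyl or an unsubstituted pyridin-2-yl would read at this position.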